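The source may report more compounds than this note shows. Statements on the series, on what has been measured and on what is new or still open speak of the compounds shown alone.

Measured so far:
Compound 1, `COc1ccc(Nc2nc(Oc3cccc(NC(=O)C=C(C)C)c3)c3sccc3n2)cc1`, gives 17600 nM in a functional assay on A-431 cells (Homo sapiens) for inhibition, read by MTT assay, with a stated time of 72 h; a higher number here means a weaker inhibitor, a lower number a stronger inhibitor.
Compound 2, `COc1ccc(Nc2nc(Oc3cccc(NC(=O)/C=C/C(C)C)c3)c3sccc3n2)cc1`, gives 25200 nM in this assay.
Compound 3, `CCC/C=C/C(=O)Nc1cccc(Oc2nc(Nc3cccc(OC)c3)nc3ccsc23)c1`, gives 8090 nM in this assay.

Among these three, compound 2 carries the highest number in this assay. Among the measured compounds shown here, its gap to compound 1, however, lies within the scatter, so the two cannot be told apart; only compound 3 stands clearly apart from compound 2, with a markedly lower number, and no single-point step links those two.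

Compound 4, `CC(C)/C=C/C(=O)Nc1cccc(Oc2nc(Nc3cccc(C#N)c3)nc3ccsc23)c1`, differs from compound 2 in one place: 3-cyanophenyl in place of 4-methoxyphenyl on a nitrogen on an aromatic ring. For the measured compounds named here, all measured steps concern the chain attached to the carbonyl carbon, and the one direct step, a 1.4-fold higher number from compound 1 to compound 2 (0.16 log units; within the scatter), is small. Going by the values given here, no measured step touches the group on the ring nitrogen, so nothing bears directly on this change. The expected step is therefore a 1.3-fold lower number from compound 2 to compound 4 (0.10 log units; within the scatter), which is to say none beyond the scatter, with a wide range to reflect the missing precedent. Compound 4 is accordingly estimated at 20000 nM, expected to fall between 5000 nM and 80000 nM.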

Compound 4, half-maximal inhibitory concentration: 24100 nM
Compound 4: the middle estimate sits 1.2-fold (0.08 log units) below what was measured; low and high end bracket the measured number.
By their numbers in this assay, from the lowest: compound 3; then compounds 1, 4 and 2 (each within the scatter of the next).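

In this assay, among the compounds shown here, this is the first measured change to the group on the ring nitrogen, and it does not move the number beyond the scatter (the step is a 1.0-fold lower number from compound 2 to compound 4 (0.02 log units; within the scatter)). Compounds 2 and 4 cannot be told apart, so with this chain on the carbonyl carbon, 3-cyanophenyl and 4-methoxyphenyl read the same even though a nitrile replaces a methoxy group. No measurement here explains why these two groups give such similar numbers.

From the compounds shown here alone, it remains open whether a different kind of group on that nitrogen, such as a phenyl ring carrying an amine or a carboxylic acid, would shift the number beyond the scatter. Going by these compounds, it is also open whether the same swap would read alike with a longer chain on the carbonyl carbon.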